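Same Chain Branching Tried on a Second Core

This account rests on a few compounds, and the source may have more. Where it says the series, first, only, none or still open, it means among the compounds named here.

Measured compounds:
compound 1 `Cc1cc(Oc2ccc(-c3ccn(CCC(C)C)c(=O)c3C#N)cc2)ccn1`: 266%
compound 2 `CCCCn1ccc(-c2ccc(Oc3ccnc(C)c3)cc2)c(C#N)c1=O`: 243%
compound 3 `CCCCn1ccc(-c2ccc(Oc3ccc(C)nc3C)cc2)c(C#N)c1=O`: 239%

All three were measured in a functional assay on CHO cells for positive allosteric modulation of metabotropic glutamate receptor 2 (Homo sapiens), read by scintillation counting and GTPgammaS binding, with a stated time of 30 min; a higher number here means a larger maximal response, a lower number a smaller maximal response. Compound 2 and compound 1 differ by methyl in place of hydrogen on a saturated chain carbon bound to two saturated chain carbons, and this gave a number 23 percentage points higher from compound 2 to compound 1 (beyond the scatter). Compound 2 and compound 3 differ in their cores by 2,6-dimethylpyridin-3-yl in place of 2-methylpyridin-4-yl on an oxygen on an aromatic ring, with a number 4 percentage points lower from compound 2 to compound 3 (within the scatter). Compound 4 `Cc1ccc(Oc2ccc(-c3ccn(CCC(C)C)c(=O)c3C#N)cc2)c(C)n1` has not been measured. It differs from compound 3 by methyl in place of hydrogen on a saturated chain carbon bound to two saturated chain carbons, the same change as from compound 2 to compound 1, at a place described in the same words. Resting on the step from compound 2 to compound 1 a number 23 percentage points higher from compound 2 to compound 1 (beyond the scatter), the step from compound 3 to compound 4 in this assay is expected to be of about the same size, a number 21 percentage points higher from compound 3 to compound 4 (beyond the scatter). For compound 4 the expected value is 260%, with a range from 232% to 290%.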

Compound 4, largest response reached (Emax), in percent of the reference or control that the assay uses: 246%
Estimate against measurement, compound 4: 14 percentage points above; the measured number falls inside the stated range.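

Placing the methyl on the chain of compound 3 gave a number 7 percentage points higher from compound 3 to compound 4 (within the scatter), so in this assay the change did not carry over at the size seen on the other core: the same change on two cores in this assay, a number 23 percentage points higher (beyond the scatter) from compound 2 to compound 1 and a number 7 percentage points higher (within the scatter) from compound 3 to compound 4, 16 percentage points apart, beyond the scatter of two such steps. With the isopentyl chain in place, 2,6-dimethylpyridin-3-yl in place of 2-methylpyridin-4-yl gave a number 20 percentage points lower from compound 1 to compound 4 (beyond the scatter), so the two changes do not simply add: the same change on two cores in this assay, a number 4 percentage points lower (within the scatter) from compound 2 to compound 3 and a number 20 percentage points lower (beyond the scatter) from compound 1 to compound 4, 16 percentage points apart, beyond the scatter of two such steps. These four compounds show that the size of the methyl step depends on the core here, but they do not show why, or how it would behave on any other core.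

On these data alone, whether a longer chain or a chain ending in a cyclopropyl ring would widen or narrow this gap remains open. So does the effect of an amine or a methoxy group on the pyridine ring.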